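Benzoyl(methyl)amino in place of a lactam on the shared core

The source may hold more compounds than are shown below. What is called first, only, known or untested is meant among the compounds shown, and "the series" means these compounds.

Measured compounds:
Compound 1 `CN(C)C(=O)c1cc(-c2cnc(NCc3c(F)ccc4c3CCO4)c3cn[nH]c(=O)c23)n(C)n1`: 21 mL.min-1.g-1
Compound 2 `CC1(C)CC(=O)N(c2cnc(NCc3c(F)ccc4c3CCO4)n3cnnc23)C1`: 16 mL.min-1.g-1

Two compounds have been run in an ADME assay on microsomes from liver (Homo sapiens) for metabolic stability, read by LC-MS, using NADPH, with stated times of 5 min and 30 min, tested at 1 uM; a higher number here means faster removal of the compound, a lower number slower removal. Compound 1 gives 21 mL.min-1.g-1 in this assay, and compound 2 gives 16 mL.min-1.g-1. Compound 2 holds the lower of the two numbers, but its nearest neighbour, compound 1, sits within the usual scatter of this assay, so the two values cannot be told apart with any confidence.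

The next compound, compound 3 `CN(C(=O)c1ccccc1)c1cnc(NCc2c(F)ccc3c2CCO3)n2cnnc12`, keeps the core and the side chain of compound 2 and changes one group on the core. The difference is benzoyl(methyl)amino in place of 4,4-dimethyl-2-oxopyrrolidin-1-yl on an aromatic carbon. The 4,4-dimethyl-2-oxopyrrolidin-1-yl group of compound 2 leaves and a benzoyl(methyl)amino group enters at the same aromatic carbon.

For the measured compounds named here, with no step between measured compounds to lean on, the size of this change can only be judged from the two values in hand. In this assay the number for compound 3 is expected to move by a 1.6-fold higher number from compound 2 to compound 3 (0.19 log units; within the scatter), a modest rise that may still fall within the scatter. Compound 3 is therefore estimated at 25 mL.min-1.g-1, with a range from 12 mL.min-1.g-1 to 50 mL.min-1.g-1.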

Compound 3, intrinsic clearance in microsomes: > 300 mL.min-1.g-1
Compound 3: only a limit was reported; the forecaster's own chance of this, stated with the estimate: 5%; at least 12-fold (1.07 log units) between middle value and limit.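

For the compounds shown here, exchanging the 4,4-dimethyl-2-oxopyrrolidin-1-yl group for benzoyl(methyl)amino on this aromatic carbon gave the first reading of what a change in one place does to the shared core in this assay, and the effect is large, with an at least 18-fold higher number from compound 2 to compound 3 (1.27 log units; beyond the scatter). The step comes with no shift in the counts of hydrogen-bond donors, hydrogen-bond acceptors or net charge, which are the same for both groups, so those counts do not separate compound 2 from compound 3, whereas the ring type does: a five-membered non-aromatic ring leaves and a six-membered aromatic ring of carbon only enters. The reading for compound 3 is a limit of the assay and not a number, so the step has a lower bound but no known size: the limit of > 300 mL.min-1.g-1 in this assay, at which 1 of the 3 values shown sits.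

The compounds shown leave open whether the rise follows the entering carbon-only aromatic ring or the loss of the lactam ring, a question that an acetyl(methyl)amino group on the same aromatic carbon would help to separate. Going by these compounds, it also remains open whether benzoyl(methyl)amino would act in the same way on the core of compound 1.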